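A few compounds are considered here, and "the series" means these few. Any claim that something is new, unique, unknown or untested is made for them only; others in the source may bear on it.

Measured so far in a functional assay on PC-3 cells (Homo sapiens) for cytotoxicity; a lower number here means that less compound is needed, a higher number that more compound is needed for the effect:
- compound 1 `COC1=C(C)C(=O)/C(=C(O)/C=C/c2ccccc2OC)C(=O)C1(C)C`: 15.6 ug/mL
- compound 2 `COC1=C(C)C(=O)/C(=C(O)/C=C/c2ccc(O)cc2)C(=O)C1(C)C`: > 20 ug/mL (a limit, not a number)
- compound 3 `COC1=C(C)C(=O)/C(=C(O)/C=C/c2ccc(F)cc2)C(=O)C1(C)C`: 7.2 ug/mL

Compound 3, at 7.2 ug/mL, has the lower of the two true numbers in this assay. Among the compounds with values here, the only other value is the limit of compound 2. The next analogue is compound 4 `COC1=C(C)C(=O)/C(=C(O)/C=C/c2ccccc2C)C(=O)C1(C)C`, and the change is 2-methylphenyl in place of 4-fluorophenyl on a double-bonded chain carbon bound to a double-bonded chain carbon: 2-methylphenyl in place of 4-fluorophenyl.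

Within the data shown here, no measured step makes exactly this change. The most relevant one is a 2.2-fold lower number from compound 1 to compound 3 (0.34 log units; beyond the scatter), with 4-fluorophenyl in place of 2-methoxyphenyl. Compound 4 keeps a 2-substituted phenyl like compound 1, but with methyl rather than methoxy, so it should lie closer to compound 1 than to compound 3. The step of an at least 2.7-fold lower number from compound 2 to compound 3 (0.44 log units; beyond the scatter) bears less directly, since it concerns hydroxy and rests on a limit, as does an at least 1.2-fold higher number from compound 1 to compound 2 (0.10 log units; that floor lies within the scatter).

Among the measured compounds shown here, a small step towards a higher number is therefore expected, no larger than the one separating compound 1 and compound 3. The expected step is a 1.7-fold higher number from compound 3 to compound 4 (0.22 log units; within the scatter). For compound 4 the estimated value is 12 ug/mL, with an expected range of 5 ug/mL to 20 ug/mL.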

Compound 4, concentration for half-maximal effect: 9 ug/mL
For compound 4 the middle estimate is 1.3-fold (0.12 log units) above the measured one; the range from low to high includes it.
By their numbers in this assay, from the lowest: compounds 3, 4 and 1 (each within the scatter of the next, the first and the last beyond it). At a limit, above all of these: compound 2.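

In this assay, exchanging 4-fluorophenyl for 2-methylphenyl on a double-bonded chain carbon bound to a double-bonded chain carbon gives a 1.3-fold higher number from compound 3 to compound 4 (0.10 log units; within the scatter), so a fluorine-free aryl group is not separated from the fluorinated one. The exchange of methoxy for methyl on an aromatic carbon gives a 1.7-fold lower number from compound 1 to compound 4 (0.24 log units; within the scatter), which places compound 4 within the scatter of both compound 1 and compound 3, although those two lie beyond the scatter of each other. Exchanging 4-hydroxyphenyl for 2-methylphenyl gives an at least 2.2-fold lower number from compound 2 to compound 4 (0.34 log units; beyond the scatter), a floor beyond the scatter that rests on a limit and not on a number: the limit of > 20 ug/mL in this assay, at which 1 of the 4 values shown sits.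

The compounds shown hold no pair with the same substituent on two different aromatic carbons, so the place of a substituent and its identity cannot yet be told apart. On these data alone, it also remains open whether an amine or a carboxylic acid on the phenyl ring, or a longer chain on the shared core, would stay within the span of compounds 3, 4 and 1.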